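Fluoropyridine replacing the oxygen ring: working notes

A few compounds are considered here, and "the series" means these few. Any claim that something is new, unique, unknown or untested is made for them only; others in the source may bear on it.

Measured in a functional assay on KYSE-70 cells for antiproliferative activity against KYSE-70 cell line (Homo sapiens), read by MTT assay, with a stated time of 72 h; on this read-out higher numbers stand for weaker inhibition and lower numbers for stronger inhibition:
- compound 1 `O=C(Nc1cccc(F)c1)c1cc(=O)[nH]c2cc(-c3ccccc3)ccc12`: > 20000 nM (a limit)
- compound 2 `O=C(Nc1cccc(F)c1)c1cc(=O)[nH]c2cc(-c3cccc(F)c3)ccc12`: 12000 nM
- compound 3 `O=C(Nc1cccc(F)c1)c1cc(=O)[nH]c2cc(C3=CCOCC3)ccc12`: 10500 nM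

Compound 3 has one numeric neighbour in this assay, namely compound 2, and the two cannot be separated. The gap is a 1.1-fold lower number from compound 2 to compound 3 (0.06 log units; within the scatter). Compound 1 gives only a limit, > 20000 nM. The steps away from it are floors: an at least 1.6-fold lower number from compound 1 to compound 2 (0.22 log units; that floor lies within the scatter) and an at least 1.9-fold lower number from compound 1 to compound 3 (0.27 log units; that floor lies within the scatter).

The next analogue is compound 4 `O=C(Nc1cccc(F)c1)c1cc(=O)[nH]c2cc(-c3ccc(F)nc3)ccc12`, which carries 6-fluoropyridin-3-yl on the same aromatic carbon where compound 3 carries its non-aromatic ring. The change is a group of 7 heavy atoms (5 carbon, 1 nitrogen, 1 fluorine; one six-membered aromatic ring with 1 hetero atom) in place of a group of 6 heavy atoms (5 carbon, 1 oxygen; one six-membered non-aromatic ring with 1 hetero atom), on an aromatic carbon. Compound 2, at 12000 nM, is the nearest measured analogue, with a fluorine-bearing aromatic ring at that place. Among the measured compounds shown here, no measured step covers a ring nitrogen, so none beyond the scatter is expected. The estimated step is a 1.1-fold lower number from compound 3 to compound 4 (0.02 log units; within the scatter). The estimate for compound 4 is 10000 nM, with an expected range of 4000 nM to 22000 nM.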

Compound 4, half-maximal inhibitory concentration: > 20000 nM
Compound 4 was reported as a limit (the forecaster's own chance of this, stated with the estimate: 20%); middle value at least 2.0-fold (0.30 log units) from the limit.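

In this assay compound 4 gives only a limit, > 20000 nM, so a fluorine-bearing aromatic ring at this position does not by itself give a numeric value, as it does in compound 2. Placing 6-fluoropyridin-3-yl here gives an at least 1.9-fold higher number from compound 3 to compound 4 (0.27 log units; that floor lies within the scatter) and an at least 1.6-fold higher number from compound 2 to compound 4 (0.22 log units; that floor lies within the scatter); both floors lie within the scatter, so neither change is shown to weaken inhibition, and the true size of each step stays hidden. The step from compound 1 cannot be read, as both compounds sit at a limit: the limit of > 20000 nM in this assay, at which 2 of the 4 values shown sit.

Open, on these data alone, is whether any group at this position can separate from compound 2 and compound 3 beyond the scatter. A pyridine without fluorine, or a ring carrying an amine or a carboxylic acid, would bear on this.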